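The source may report more compounds than this note shows. Statements on the series, on what has been measured and on what is new or still open speak of the compounds shown alone.

Working notes on the series

Of the compounds shown here, three of the shared core have been measured, differing only in the group on the amide-type nitrogen in the ring: compound 1 `O=C1COc2ccc(-c3cccc(NS(=O)(=O)c4ccc(F)cc4)c3)cc2N1C1CC1` carries cyclopropyl, compound 2 `CC(C)N1C(=O)COc2ccc(-c3cccc(NS(=O)(=O)c4ccc(F)cc4)c3)cc21` isopropyl, and compound 3 `O=C1COc2ccc(-c3cccc(NS(=O)(=O)c4ccc(F)cc4)c3)cc2N1c1ccc(F)cc1` 4-fluorophenyl. In a functional assay on A-375 cells (Homo sapiens) for antiproliferative activity, read by MTT assay, with a stated time of 72 h (on this read-out lower numbers stand for stronger inhibition and higher numbers for weaker inhibition), compound 1 reaches only a limit of the assay, > 40000 nM. In this assay compound 2 likewise reaches only a limit, > 40000 nM. In this assay compound 3 also reaches only a limit, > 40000 nM. The steps between them cannot be sized: a step that the two limits leave unreadable from compound 1 to compound 2, a step that the two limits leave unreadable from compound 1 to compound 3 and a step that the two limits leave unreadable from compound 2 to compound 3 are all unreadable because of the limit of > 40000 nM in this assay, at which 3 of the 3 values shown sit. Compound 3 therefore stands at the limit together with the other two, with no ordering among them to be drawn.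

Compound 4 `COc1cccc(N2C(=O)COc3ccc(-c4cccc(NS(=O)(=O)c5ccc(F)cc5)c4)cc32)c1` is the next member. The change from compound 3 is 3-methoxyphenyl in place of 4-fluorophenyl on an amide-type nitrogen in a ring. Of the measured steps, all three bear on the same position, and none gave a readable size; every group tried there has left the value at the limit. No basis exists for expecting a step beyond the scatter, so compound 4 is expected to remain at the limit, with an estimated step of a number no higher from compound 3 to compound 4 (the limit leaves the size open). The estimate for compound 4 in this assay is 40000 nM, with a range from 15000 nM to 100000 nM.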

Compound 4, half-maximal inhibitory concentration: > 40000 nM
Compound 4 gave a limit, no number; the forecaster's own chance of this, stated with the estimate: 80%; the middle value lies on the limit itself.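

No new step can be read from compound 4 to compound 1, compound 2 or compound 3 in this assay, because all four compounds stand at the same assay limit: the limit of > 40000 nM in this assay, at which 4 of the 4 values shown sit.

The compounds shown leave open whether any group on the amide-type nitrogen in a ring has a readable effect on the value, and of what size.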